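Chain length at the carbonyl-bound oxygen: compound 4

The compounds below may be only part of what the source reports. "The series", "measured", "known", "first", "only" and "open" are said of these compounds alone.

Among the compounds with values here, compound 3 `CCCCCCCOC(=O)CCC(=O)N1CCN(CCCOc2cc3c(Nc4ccc(F)c(Cl)c4)ncnc3cc2OC)CC1` gives 59.1% in a functional assay on A549 cells (Homo sapiens) for cytotoxicity, read by MTT assay, with a stated time of 24 h, tested at 40 uM (on this read-out lower numbers stand for a stronger effect and higher numbers for a weaker effect at the one concentration tested), and has the smallest of the three numbers so far, though its gap to compound 1 `CCOC(=O)CCC(=O)N1CCN(CCCOc2cc3c(Nc4ccc(F)c(Cl)c4)ncnc3cc2OC)CC1`, which gives 67.4%, is within the scatter, while its gap to compound 2 `CCCOC(=O)CCC(=O)N1CCN(CCCOc2cc3c(Nc4ccc(F)c(Cl)c4)ncnc3cc2OC)CC1`, which gives 80.9%, is beyond it. Compound 4 `CCCCCCCCCCCCCOC(=O)CCC(=O)N1CCN(CCCOc2cc3c(Nc4ccc(F)c(Cl)c4)ncnc3cc2OC)CC1` differs from compound 3 by hexyl in place of hydrogen on a saturated chain carbon, seven bonds along the chain from an oxygen next to a carbonyl group. The steps of the same kind are a number 8.3 percentage points lower from compound 1 to compound 3 (within the scatter) and a number 21.8 percentage points lower from compound 2 to compound 3 (beyond the scatter), whereas a number 13.5 percentage points higher from compound 1 to compound 2 (beyond the scatter), so the chain length has not moved this assay in one direction, compound 2 going against a downward trend. A step of a number 4.1 percentage points lower from compound 3 to compound 4 (within the scatter) is therefore expected, downward but within the scatter. Compound 4 is estimated at 55%, within a range of 40% to 72%.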

Compound 4, a percentage reported as activity, at one concentration (the size of the read-out at that concentration, not a potency): 71.1%
Compound 4: the middle estimate sits 16.1 percentage points below what was measured; low and high end bracket the measured number.
By their numbers in this assay, from the lowest: compounds 3, 1, 4 and 2 (each within the scatter of the next, the first and the last beyond it).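

In this assay, adding hexyl at this place does not extend the lower numbers seen with compound 3: a number 12 percentage points higher from compound 3 to compound 4 (beyond the scatter). The longest chain shown is not separated from either shorter ester, with a number 3.7 percentage points higher from compound 1 to compound 4 (within the scatter) and a number 9.8 percentage points lower from compound 2 to compound 4 (within the scatter), so these four compounds show no single direction with chain length, and compound 3 is the only one separated from compound 4. No measurement available here explains the reversal at the longest chain.

The compounds shown leave open how a longer chain at this place would read, and whether a carboxylic acid in place of the ester would change the number.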